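From methyl to ethyl on compound 3

The source may hold more compounds than are shown below. What is called first, only, known or untested is meant among the compounds shown, and "the series" means these compounds.

Compound 1 `CCN1CCN(CCC(=O)Nc2ccc3[nH]c(-c4ccc(Br)cc4)nc3c2)CC1`: 27400 nM
Compound 2 `Cc1ccc(-c2nc3cc(NC(=O)CN4CCN(C)CC4)ccc3[nH]2)cc1`: > 50000 nM, a limit
Compound 3 `Cc1ccc(-c2nc3cc(NC(=O)CCN4CCN(C)CC4)ccc3[nH]2)cc1`: > 50000 nM, a limit

In a functional assay on HepG2 cells (Homo sapiens) for cytotoxicity, read by MTT assay, with a stated time of 72 h (a lower number here means a stronger inhibitor, a higher number a weaker inhibitor), compound 3 reads > 50000 nM, which is a limit and not a number. Compound 4 `CCN1CCN(CCC(=O)Nc2ccc3[nH]c(-c4ccc(C)cc4)nc3c2)CC1` differs from it by a single change, 4-methylpiperazin-1-yl to 4-ethylpiperazin-1-yl: methyl in place of hydrogen on a saturated chain carbon bound to an amine nitrogen in a ring. Among the measured compounds shown here, the only measured step, a step that the two limits leave unreadable from compound 2 to compound 3, concerns a different change and gives no size to work from. Compound 1 also carries 4-ethylpiperazin-1-yl and gives a real number, 27400 nM. For the measured compounds named here, with compound 1 at 27400 nM as the only guide, a small move toward stronger inhibition is expected, perhaps nothing beyond the scatter. The expected step is an at least 1.1-fold lower number from compound 3 to compound 4 (0.04 log units; that floor lies within the scatter). Compound 4 is estimated at 45000 nM, with an expected range from 22000 nM to 90000 nM.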

Compound 4, half-maximal inhibitory concentration: 14600 nM
The estimate for compound 4 lay 3.1-fold (0.49 log units) above the measured number, and the stated range ends above it.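

Among the compounds shown here, changing 4-methylpiperazin-1-yl to 4-ethylpiperazin-1-yl gives the first step of readable size for this position in this assay, an at least 3.4-fold lower number from compound 3 to compound 4 (0.53 log units; beyond the scatter). Putting (4-ethylpiperazin-1-yl)methyl in place of 4-methylpiperazin-1-yl gives an at least 3.4-fold lower number from compound 2 to compound 4 (0.53 log units; beyond the scatter), while methyl in place of bromo on an aromatic carbon gives a 1.9-fold lower number from compound 1 to compound 4 (0.27 log units; within the scatter), so that swap does not separate the two compounds. The first two steps are only floors, because compound 2 and compound 3 each rest on a limit and not a number: the limit of > 50000 nM in this assay, at which 2 of the 4 values shown sit.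

As far as these compounds go, whether a propyl or a 2-hydroxyethyl group in place of the ethyl would move the number further remains open.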